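Notes on the step from compound 3 to compound 4

The source may hold more compounds than are shown below. What is called first, only, known or untested is meant among the compounds shown, and "the series" means these compounds.

Measured in a physicochemical assay for lipophilicity, using the shake flask method, in phosphate buffer, measured as octanol-water partition, with a stated time of 30 min, at pH 7.4; on this read-out higher numbers stand for higher lipophilicity and lower numbers for lower lipophilicity:
- compound 1 `Cc1nc(CO)ccc1-c1cnc(NCc2c(F)ccc3c2CCO3)c2cn[nH]c(=O)c12` gives 2.4
- compound 2 `CC(=O)N1CCC(c2cnc(NCc3c(F)ccc4c3CCO4)c3cn[nH]c(=O)c23)CC1` gives 2.9
- compound 3 `CNC(=O)c1ccc(-c2cnc(NCc3c(F)ccc4c3CCO4)c3cn[nH]c(=O)c23)c(C)n1` gives 2.9

Compound 2 stands level with compound 3 at 2.9 in this assay, together the highest of the three numbers, and compound 1 lies lower.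

The next compound, compound 4 `CN(c1ccn(C)n1)c1cnc(NCc2c(F)ccc3c2CCO3)c2cn[nH]c(=O)c12`, has not been measured. It carries methyl(1-methyl-1H-pyrazol-3-yl)amino in place of 2-methyl-6-(methylcarbamoyl)pyridin-3-yl on an aromatic carbon.

Two measured exchanges at this same carbon bear on the change. The closer guide is no change at the digits printed from compound 2 to compound 3 (within the scatter), since the group now leaving entered there. The other is a number 0.50 log units higher from compound 1 to compound 2 (beyond the scatter), which is modest. A third step, a number 0.50 log units higher from compound 1 to compound 3 (beyond the scatter), brought in the methylcarbamoyl that now leaves with the rest of its group. Going by the values given here, none of the three involves the entering group, so the series offers no direct precedent for it.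

With the largest of these steps only modest, no shift beyond the scatter is expected in this assay. The estimated change is a number 0.10 log units lower from compound 3 to compound 4 (within the scatter), and a slight fall is the expected direction, if any. For compound 4 the estimate is 2.8, with an expected range of 2.3 to 3.2.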

Compound 4, distribution coefficient: 2.4
The estimate for compound 4 lay 0.40 log units above the measured number; the range from low to high includes it.
By their numbers in this assay, from the lowest: compounds 1 and 4 (each within the scatter of the next); then compounds 2 and 3 (each within the scatter of the next).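

In this assay, this aromatic carbon now gives a step beyond the scatter when methyl(1-methyl-1H-pyrazol-3-yl)amino replaces 2-methyl-6-(methylcarbamoyl)pyridin-3-yl, a number 0.50 log units lower from compound 3 to compound 4 (beyond the scatter), and another when it replaces 1-acetylpiperidin-4-yl, a number 0.50 log units lower from compound 2 to compound 4 (beyond the scatter), although the exchange between those two leaving groups gave none. Against 6-(hydroxymethyl)-2-methylpyridin-3-yl the same entering group gives no change at the digits printed from compound 1 to compound 4 (within the scatter), so the four compounds form two groups at this position, compounds 1 and 4 in one and compounds 2 and 3 in the other, and each contains two quite different substituents. Nothing measured on these compounds accounts for this split.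

The compounds shown leave open which part of the entering group goes with the step: the methyl on the amino nitrogen, the amino nitrogen itself, or the 1-methyl-1H-pyrazol-3-yl ring, which could be separated by the secondary amine lacking that methyl and by the same ring joined directly to the aromatic carbon. Going by these compounds, it also remains open where a carboxylic acid or a piperidin-4-yl with a free ring amine would stand relative to these two groups.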